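The source may report more compounds than this note shows. Statements on the series, on what has been measured and on what is new or still open speak of the compounds shown alone.

Measured compounds:
compound 1 `COc1ccc(C(/C=C/c2ccc(Cl)cc2)=N/O)cc1`: 291000 nM
compound 2 `COc1ccc(C(/C=C/c2ccc(F)cc2)=N/O)cc1`: 13500 nM
compound 3 `O/N=C(\C=C\c1ccc(Cl)cc1)c1ccc(Br)cc1`: 24700 nM

All three numbers come from an ADME assay on cells (Mus musculus, strain Balb/c) for cytotoxicity, read by MTT assay, with a stated time of 48 h; on this read-out higher numbers stand for lower toxicity in this test and lower numbers for higher toxicity in this test. Compound 2 differs from compound 1 by fluoro in place of chloro on an aromatic carbon, and the step that this change made is a 22-fold lower number from compound 1 to compound 2 (1.33 log units; beyond the scatter). Compound 3 differs from compound 1 on the other ring, and its step is a 12-fold lower number from compound 1 to compound 3 (1.07 log units; beyond the scatter). Compound 2 and compound 3 lie within the scatter of each other, so no order between them is claimed.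

Compound 4 `O/N=C(\C=C\c1ccc(F)cc1)c1ccc(Br)cc1` is not yet measured in this assay. Among the measured compounds shown here, it differs from compound 3 by fluoro in place of chloro on an aromatic carbon, which is the same change as the one from compound 1 to compound 2, made at the same kind of place. The two cores on which the change is made differ by bromo in place of methoxy on an aromatic carbon.

A lower number is expected for compound 4 because the earlier step of a 22-fold lower number from compound 1 to compound 2 (1.33 log units; beyond the scatter) was large. The expected step from compound 3 is a 12-fold lower number from compound 3 to compound 4 (1.09 log units; beyond the scatter), kept smaller than the earlier one since it rests on a single pair on a different core. For compound 4 the estimate in this assay is 2000 nM, with a range from 400 nM to 12000 nM.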

Compound 4, half-maximal cytotoxic concentration: 20300 nM
Beside the measured number, compound 4's estimate is 10-fold (1.01 log units) below it; the measured number lies above the stated range.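

In this assay, fluoro in place of chloro on an aromatic carbon gives a 1.2-fold lower number from compound 3 to compound 4 (0.09 log units; within the scatter), so the size of this step does not carry over from the core of compound 1 to the core of compound 3: the same change on two cores in this assay, a 22-fold lower number (1.33 log units; beyond the scatter) from compound 1 to compound 2 and a 1.2-fold lower number (0.09 log units; within the scatter) from compound 3 to compound 4, 18-fold (1.25 log units) apart, beyond the scatter of two such steps. Bromo in place of methoxy on an aromatic carbon depends in the same way on the group at the other end of the series, with a 1.5-fold higher number from compound 2 to compound 4 (0.18 log units; within the scatter): the same change on two cores in this assay, a 12-fold lower number (1.07 log units; beyond the scatter) from compound 1 to compound 3 and a 1.5-fold higher number (0.18 log units; within the scatter) from compound 2 to compound 4, 18-fold (1.25 log units) apart, beyond the scatter of two such steps. Both large steps start from compound 1, so the two changes do not add up across these four compounds, but this does not show what sets the difference or how either change would behave on a further core.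

Open, as far as these compounds go, is whether fluoro in place of chloro would follow the large step or the small one on a core carrying an amine or a carboxylic acid in place of methoxy or bromo. Also open, from the compounds shown here alone, is what a longer chain in place of the halogen would do to the number.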